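From 3-nitrophenyl to 4-cyanophenyl on a shared core

The compounds below may be only part of what the source reports. "The series", "measured", "known", "first", "only" and "open" are said of these compounds alone.

Three measured compounds share a core and differ in one aromatic group: compound 1 `COc1cc(/C=C2\CN(C)C/C(=C\c3ccccc3F)C2=O)cc(OC)c1`, compound 2 `COc1cc(/C=C2\CN(C)C/C(=C\c3ccc(Br)cc3)C2=O)cc(OC)c1` and compound 3 `COc1cc(/C=C2\CN(C)C/C(=C\c3cccc([N+](=O)[O-])c3)C2=O)cc(OC)c1`. In a functional assay on THP-1 cells (Homo sapiens) for cytotoxicity, read by MTT assay, with a stated time of 24 h (on this read-out higher numbers stand for weaker inhibition and lower numbers for stronger inhibition), compound 1 gives 1170 nM, compound 2 gives 4270 nM and compound 3 gives 1770 nM. Compound 3 therefore stands close to compound 1, with a 1.5-fold higher number from compound 1 to compound 3 (0.18 log units; within the scatter), and apart from compound 2, with a 2.4-fold lower number from compound 2 to compound 3 (0.38 log units; beyond the scatter).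

Compound 4 `COc1cc(/C=C2\CN(C)C/C(=C\c3ccc(C#N)cc3)C2=O)cc(OC)c1` has not yet been measured. It carries 4-cyanophenyl in place of 3-nitrophenyl on a double-bonded chain carbon bound to a double-bonded ring carbon. Within the data shown here, no measured compound has this group, so the evidence is limited to the other swaps at the same place. The largest of these is a 3.6-fold higher number from compound 1 to compound 2 (0.56 log units; beyond the scatter), which leads to the 4-bromophenyl group of compound 2. These steps are all modest or smaller, so only a small change is expected, namely a 1.2-fold higher number from compound 3 to compound 4 (0.09 log units; within the scatter). For compound 4 the estimated value in this assay is 2200 nM, with an expected range from 1000 nM to 4800 nM.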

Compound 4, half-maximal inhibitory concentration: 940 nM
The estimate for compound 4 lay 2.3-fold (0.37 log units) above the measured number; measured number outside the range, below it.
By their numbers in this assay, from the lowest: compounds 4, 1 and 3 (each within the scatter of the next); then compound 2.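

In this assay, the 4-cyanophenyl group falls in one band with the 2-fluorophenyl and 3-nitrophenyl groups (a 1.9-fold lower number from compound 3 to compound 4 (0.27 log units; within the scatter); a 1.2-fold lower number from compound 1 to compound 4 (0.10 log units; within the scatter)), so neither swap leads beyond the scatter. Cyano in place of bromo on an aromatic carbon gives the largest step at this place so far (a 4.5-fold lower number from compound 2 to compound 4 (0.66 log units; beyond the scatter)), which leaves compound 2 alone in showing the higher number and shows that the 4-cyanophenyl group of compound 4 does not share it. No measurement shown here accounts for this difference between cyano and bromo.

Going by these compounds, all four compounds carry a substituted phenyl group at this place, so what an amine or a carboxylic acid on that ring, or a longer chain in place of it, would give remains open. On these data alone, the rest of the shared core stays the same throughout, so the effect of a swap elsewhere on it is also open.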